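The source may report more compounds than this note shows. Statements on the series, on what has been measured and on what is new or still open speak of the compounds shown alone.

Two compounds of this set have numbers. Compound 1 `CCSC(=S)N[C@H]1CCOC1=O` is the outlier in structure. In a functional assay on SMMC-7721 cells (Homo sapiens) for cytotoxicity, read by MTT assay, with a stated time of 72 h (on this read-out higher numbers stand for weaker inhibition and lower numbers for stronger inhibition), compound 1 gives only a limit, > 128000 nM, and no number; this is the line (the limit of > 128000 nM in this assay, at which 1 of the 2 values shown sits). Among the measured compounds shown here, compound 2 `O=C(CCl)Nc1ccc(C(=O)/C=C/c2ccc(Br)cc2)cc1` is the one measured number of the set. In this assay compound 2 gives 13300 nM, so it stands alone as the sole point against which anything else can be set.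

Compound 3 `O=C(CCl)Nc1ccc(C(=O)/C=C/c2ccccc2Cl)cc1` differs from compound 2 in one place: 2-chlorophenyl in place of 4-bromophenyl on a double-bonded chain carbon bound to a double-bonded chain carbon. For the measured compounds named here, no measured pair in the set shows the effect of such a halogen-aryl swap, so there is nothing to lean on beyond the single value of compound 2. The change is expected to stay within the scatter of repeat measurements, with a step from compound 2 to compound 3 of a 1.2-fold higher number from compound 2 to compound 3 (0.08 log units; within the scatter) in this assay. Compound 3 is therefore estimated in this assay at 16000 nM, with a plausible range from 6000 nM to 45000 nM.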

Compound 3, half-maximal inhibitory concentration: 11100 nM
The estimate for compound 3 lay 1.4-fold (0.16 log units) above the measured number; measured number inside the range.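

Among the compounds shown here, on a double-bonded chain carbon bound to a double-bonded chain carbon, 2-chlorophenyl in place of 4-bromophenyl gives a 1.2-fold lower number from compound 2 to compound 3 (0.08 log units; within the scatter) in this assay and is the first step that can be read between two measured compounds. At this place, the two aryl groups give numbers that stay within the scatter of each other, although they differ both in the halogen and in where it sits, and this single pair does not separate those two changes. No measured property on hand bears on this step.

Open, from the compounds shown here alone, is whether a phenyl carrying an amine or a carboxylic acid at this place would move the number beyond the scatter. Also open, going by these compounds, is how far this result holds on any other core, as the reading rests on one pair.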